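Cytotoxicity in the triazole series: fluoro to trifluoromethyl

This account rests on a few compounds, and the source may have more. Where it says the series, first, only, none or still open, it means among the compounds named here.

Measured so far, in an ADME assay on HEK293 cells (Homo sapiens) for cytotoxicity, read by sulforhodamine B assay, with a stated time of 48 h, tested at 10 uM; on this read-out higher numbers stand for more inhibition at the one concentration tested (going by the name of the read-out) and lower numbers for less inhibition:
compound 1 `COc1nc2ccc(Br)cc2cc1C(c1ccccc1)n1cc(-c2ccccc2F)nn1`: 3.97%
compound 2 `COc1nc2ccc(Br)cc2cc1C(c1ccccc1)n1cc(CCCO)nn1`: 27.4%
compound 3 `COc1nc2ccc(Br)cc2cc1C(c1ccccc1)n1cc(CO)nn1`: 11.5%

Compound 1 gives the lowest number of the three; compound 3 sits within the scatter of it, while compound 2 lies beyond, by a number 23.4 percentage points higher from compound 1 to compound 2 (beyond the scatter). The step of a number 7.5 percentage points higher from compound 1 to compound 3 (within the scatter) is within the scatter, and between the two hydroxyalkyl compounds the change is a number 15.9 percentage points lower from compound 2 to compound 3 (beyond the scatter).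

The next compound, compound 4 `COc1nc2ccc(Br)cc2cc1C(c1ccccc1)n1cc(-c2ccccc2C(F)(F)F)nn1`, differs from compound 1 by trifluoromethyl in place of fluoro on an aromatic carbon. Within the data shown here, none of the measured steps touches this place: each of them exchanges the whole 2-fluorophenyl for a hydroxyalkyl chain, so they say nothing direct about swapping one substituent on the ring for another. Among the measured compounds shown here, the only anchor is compound 1 itself, which sits at the low end of this read-out.

On that basis the step of a number 2 percentage points higher from compound 1 to compound 4 (within the scatter) is expected to stay within the scatter, with no clear direction. Compound 4 is estimated at 6%, in a range from -6% to 20%.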

Compound 4, a percentage reported as inhibition, at one concentration (the size of the read-out at that concentration, not a potency): 14.3%
Estimate against measurement, compound 4: 8.3 percentage points below, and the stated range covers the measured number.
By their numbers in this assay, from the lowest: compounds 1, 3 and 4 (each within the scatter of the next, the first and the last beyond it); then compound 2.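

In this assay, among these compounds, the substituent on the aromatic carbon ortho to a large group is not silent: trifluoromethyl in place of fluoro gives a number 10.3 percentage points higher from compound 1 to compound 4 (beyond the scatter), the first reading at this place with the aryl ring kept. Set against the hydroxyalkyl compounds, the 2-(trifluoromethyl)phenyl group gives a number 2.8 percentage points higher from compound 3 to compound 4 (within the scatter) and a number 13.1 percentage points lower from compound 2 to compound 4 (beyond the scatter), so it stays apart from the 3-hydroxypropyl chain but not from hydroxymethyl. Nothing available on these compounds accounts for the change at this place.

With only fluoro and trifluoromethyl at this carbon, the step cannot yet be assigned to the number of fluorine atoms or to the added carbon. Methyl, chloro or methoxy at the same carbon would separate the two, and an amine or a carboxylic acid there would extend the range of groups.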